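Solubility of a cyclohexyl analogue built from compound 3

This account rests on a few compounds, and the source may have more. Where it says the series, first, only, none or still open, it means among the compounds named here.

Of the compounds shown here, three sharing one core have been measured in a physicochemical assay for solubility, at pH 7.4; a lower number here means a less soluble compound, a higher number a more soluble compound. Compound 1 `CCCCCCCc1cnc(-c2ccc(CNC(=O)[C@H]3NCC[C@@H]3O)cc2)s1` gives 4.2 ug/mL. Compound 2 `CCCCCCCc1cn(-c2ccc(CNC(=O)[C@H]3NCC[C@@H]3O)cc2)nn1` gives 3.1 ug/mL. For compound 3 `O=C(NCc1ccc(-c2noc(CCC3CC3)n2)cc1)[C@H]1NCC[C@@H]1O` the result is a limit of the assay rather than a number, reported as > 50 ug/mL. Among the compounds with values here, compound 3 thus stands at the upper end of what this set shows, at the limit of > 50 ug/mL in this assay, at which 1 of the 3 values shown sits, while compound 1 and compound 2 sit far below it; no step between them and compound 3 has been computed, so their values are stated only as they stand.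

Compound 4 `O=C(NCc1ccc(-c2noc(CCC3CCCCC3)n2)cc1)[C@H]1NCC[C@@H]1O` has not yet been measured in this assay. It differs from compound 3 in one place: cyclohexyl in place of cyclopropyl on a saturated chain carbon, two bonds along the chain from an aromatic carbon. Nothing in the measured set gives a cause for what this change will do, so the expectation rests on the structural change alone.

Compound 4 is expected to fall below the limit seen for compound 3, with a step of an at least 4.1-fold lower number from compound 3 to compound 4 (0.61 log units; beyond the scatter) estimated, a move downward beyond the usual scatter. The estimated value for compound 4 in this assay is 12 ug/mL. The expected range for compound 4 runs from 3 ug/mL to 45 ug/mL, and a result again reported only as a limit cannot be ruled out.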

Compound 4, solubility: 26 ug/mL
For compound 4 the middle estimate is 2.2-fold (0.34 log units) below the measured one, within the range that was stated.
By their numbers in this assay, from the lowest: compounds 2 and 1 (each within the scatter of the next); then compound 4. At a limit, above all of these: compound 3.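

The result for compound 3 in this assay is a limit of the assay and not a number: the limit of > 50 ug/mL in this assay, at which 1 of the 4 values shown sits. Cyclohexyl in place of cyclopropyl at this position therefore yields a step known only by its floor, an at least 1.9-fold lower number from compound 3 to compound 4 (0.28 log units; that floor lies within the scatter), so the change is not shown to move the number beyond the scatter, and its true size remains unknown. Compound 4 does give this position a reading that is an actual number rather than a limit, which the earlier compounds did not provide, but nothing shown gives a cause for the step.

From the compounds shown here alone, how far the number truly moves with this change stays open as long as compound 3 has only a limit, and a single pair cannot say whether the size of the saturated ring matters in general or what cyclobutyl or cyclopentyl would give in the same place. Equally open, going by these compounds, is how an amine, a carboxylic acid or a longer chain would read at this position on the core shared by compound 3 and compound 4.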